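This account rests on a few compounds, and the source may have more. Where it says the series, first, only, none or still open, it means among the compounds named here.

Measured in an ADME assay on HepG2 cells (Homo sapiens) for cytotoxicity, read by XTT assay, with a stated time of 16 h; a lower number here means a stronger inhibitor, a higher number a weaker inhibitor:

Compound 1 `Oc1ccc(-c2nc(-c3ccc(Oc4ccc(C(F)(F)F)cc4)cc3)no2)cc1`: 24.1 ug/mL
Compound 2 `FC(F)(F)c1ccc(Oc2ccc(-c3noc(-c4c[nH]cn4)n3)cc2)cc1`: 25.8 ug/mL

Within the data shown here, compound 2 holds the higher of the two numbers, but the only step to it, a 1.1-fold higher number from compound 1 to compound 2 (0.03 log units; within the scatter), is within the scatter, so the two compounds are not separated in this assay.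

Compound 3 `C#Cc1c[nH]nc1-c1nc(-c2ccc(Oc3ccc(C(F)(F)F)cc3)cc2)no1` is not yet measured. It differs from compound 2 at one place: 4-ethynyl-1H-pyrazol-3-yl in place of 1H-imidazol-4-yl on an aromatic carbon.

Among the measured compounds shown here, only one measured step exists, from compound 1 to compound 2, and it exchanged a six-membered ring bearing a hydroxyl for a five-membered aromatic ring with two hetero atoms without moving the number beyond the scatter. The change from compound 2 to compound 3 keeps a five-membered aromatic ring with two hetero atoms at the same place and adds the ethynyl substituent. For the measured compounds named here, no step on record points in either direction, so no change beyond the scatter is expected, and the step of a 1.0-fold higher number from compound 2 to compound 3 (0.00 log units; within the scatter) is estimated to stay within it. For compound 3 the expected value is 26 ug/mL, with a range of 12 ug/mL to 55 ug/mL.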

Compound 3, half-maximal inhibitory concentration: 75.7 ug/mL
The estimate for compound 3 lay 2.9-fold (0.46 log units) below the measured number; the whole stated range lies below it.
By their numbers in this assay, from the lowest: compounds 1 and 2 (each within the scatter of the next); then compound 3.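

In this assay, this position on the five-membered aromatic ring with 2 nitrogen and 1 oxygen now responds to substitution: a 2.9-fold higher number from compound 2 to compound 3 (0.47 log units; beyond the scatter), and a 3.1-fold higher number from compound 1 to compound 3 (0.50 log units; beyond the scatter). Ring type alone does not set the number, as 1H-imidazol-4-yl and 4-ethynyl-1H-pyrazol-3-yl are both five-membered aromatic rings with 2 hetero atoms and have the same donor and acceptor counts, yet they are separated beyond the scatter. No available measurement accounts for the step.

Compound 3 differs from compound 2 in both the ring and the ethynyl group, so the compounds shown cannot assign the step to either. Going by these compounds, how a 1H-pyrazol-3-yl group would read with a methyl or an amine in place of the ethynyl remains open.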